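The source may report more compounds than this note shows. Statements on the series, on what has been measured and on what is new or still open speak of the compounds shown alone.

Working notes on the series. Compound 1 `CCNC(=O)c1noc(-c2cc(C(C)C)c(O)cc2O)c1-c1cc(CO)no1`, compound 2 `CCNC(=O)c1noc(-c2cc(C(C)C)c(O)cc2O)c1-c1cc(CN)no1` and compound 3 `CCNC(=O)c1noc(-c2cc(C(C)C)c(O)cc2O)c1-c1cc(C(N)=O)no1` share one core and differ in a single group. In a functional assay on A2780 cells (Homo sapiens) for inhibition (a lower number here means a stronger inhibitor, a higher number a weaker inhibitor), compound 1 gives 5 nM, compound 3 gives 15 nM, and for compound 2 the result is "not determined" (no result reported). Compound 3 therefore holds the higher of the two numbers at hand; its nearest neighbour is compound 1, with a 3.0-fold higher number from compound 1 to compound 3 (0.48 log units; beyond the scatter). The next compound, compound 4 `CCNC(=O)c1noc(-c2cc(C(C)C)c(O)cc2O)c1-c1cnn(C)c1`, brings a change of another kind: 1-methyl-1H-pyrazol-4-yl in place of 3-carbamoyl-1,2-oxazol-5-yl on an aromatic carbon. Among the measured compounds shown here, the one measured step, a 3.0-fold higher number from compound 1 to compound 3 (0.48 log units; beyond the scatter), alters only the group carried by the leaving ring and keeps that ring, so it gives no direct precedent for exchanging the ring as a whole; it shows merely that variation at this position has so far cost little. Since the ring exchange reaches further than anything measured, a step somewhat beyond the scatter, toward a weaker inhibitor, is expected: a 2.3-fold higher number from compound 3 to compound 4 (0.37 log units; beyond the scatter). For compound 4 in this assay the estimate is 35 nM, with a range from 8 nM to 150 nM.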

Compound 4, half-maximal inhibitory concentration: 20 nM
Compound 4: the middle estimate sits 1.8-fold (0.24 log units) above what was measured; the measured number falls inside the stated range.
By their numbers in this assay, from the lowest: compound 1; then compounds 3 and 4 (each within the scatter of the next).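

In this assay, exchanging the whole ring gives a 1.3-fold higher number from compound 3 to compound 4 (0.12 log units; within the scatter), so neither the carbamoyl group nor the 1,2-oxazole ring is needed to hold a number of this size, and the smaller 1-methyl-1H-pyrazol-4-yl group serves as well as the group it replaces. Against the hydroxymethyl-bearing ring the same exchange reads a 4.0-fold higher number from compound 1 to compound 4 (0.60 log units; beyond the scatter), which leaves compound 1 with the lowest number of the three measured and shows that its 3-(hydroxymethyl)-1,2-oxazol-5-yl group is the one substituent here set apart from the others. Nothing at hand gives a reason for these numbers.

The steps involving compound 2 cannot be read, so the aminomethyl group remains unplaced in this order. Also open, going by these compounds, is whether a carboxylic acid in place of the carbamoyl group, or a longer chain in place of the methyl of the 1-methyl-1H-pyrazol-4-yl group, would keep the number in this range.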